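The compounds below may be only part of what the source reports. "The series", "measured", "known", "first", "only" and "open" are said of these compounds alone.

Working notes on the side-chain series. All three measured compounds share one core and differ only in the chain carried on the saturated carbon that bears the hydroxyl. Compound 1 `CCCC(O)C1=CC(=O)c2c(OC)ccc(OC)c2C1=O` gives 0.409 ug/mL in a functional assay on L1210 cells (Mus musculus) for cytotoxicity; on this read-out lower numbers stand for an effect already at smaller amounts and higher numbers for an effect only at larger amounts of compound. Compound 2 `CCCCCC(O)C1=CC(=O)c2c(OC)ccc(OC)c2C1=O` gives 0.378 ug/mL in this assay, and the step of a 1.1-fold lower number from compound 1 to compound 2 (0.03 log units; within the scatter) lies within the scatter. Compound 3 `CCCCCCCC(O)C1=CC(=O)c2c(OC)ccc(OC)c2C1=O` gives 1.04 ug/mL in this assay, the highest number of the three: the steps of a 2.5-fold higher number from compound 1 to compound 3 (0.41 log units; beyond the scatter) and a 2.8-fold higher number from compound 2 to compound 3 (0.44 log units; beyond the scatter) are both modest and beyond the scatter, so the longest chain goes with the highest numbers among these three.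

Compound 4 `COc1ccc(OC)c2c1C(=O)C=C(C(C)O)C2=O` is not yet measured. It differs from compound 3 by hydrogen in place of hexyl on a saturated chain carbon, two bonds along the chain from a double-bonded ring carbon and an oxygen on a saturated carbon; cut one bond further out, the same change reads heptyl to methyl, leaving a chain shorter than that of compound 1. Among the compounds with values here, the steps that bear on it are the two chain-lengthening steps a 2.5-fold higher number from compound 1 to compound 3 (0.41 log units; beyond the scatter) and a 2.8-fold higher number from compound 2 to compound 3 (0.44 log units; beyond the scatter), both modest and toward higher numbers; read in reverse they point to a lower number on shortening, while a 1.1-fold lower number from compound 1 to compound 2 (0.03 log units; within the scatter) shows no change between the two shorter chains. Within the data shown here, no measured compound has a chain shorter than that of compound 1, so the fall need not carry beyond the level of compound 1. The expected step is a 2.3-fold lower number from compound 3 to compound 4 (0.36 log units; beyond the scatter), a modest fall. Compound 4 is therefore estimated at 0.45 ug/mL in this assay, with a range from 0.15 ug/mL to 1.3 ug/mL.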

Compound 4, concentration for half-maximal effect: 0.487 ug/mL
Estimate against measurement, compound 4: 1.1-fold (0.03 log units) below, and the stated range covers the measured number.
By their numbers in this assay, from the lowest: compounds 2, 1 and 4 (each within the scatter of the next); then compound 3.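

Hydrogen in place of hexyl, on a saturated chain carbon two bonds along the chain from a double-bonded ring carbon and an oxygen on a saturated carbon, gives a 2.1-fold lower number from compound 3 to compound 4 (0.33 log units; beyond the scatter), so in this assay the short methyl end of the same change, heptyl to methyl, lands clear of the longest chain. Shortening beyond the chain of compound 1 brings no further fall: a 1.2-fold higher number from compound 1 to compound 4 (0.08 log units; within the scatter) and a 1.3-fold higher number from compound 2 to compound 4 (0.11 log units; within the scatter) both lie within the scatter, which leaves compound 1, compound 2 and compound 4 on one level and compound 3 alone apart from them. The shift in this series is therefore tied to the longest chain and is not an even effect of each added length, as the same chain extension reads differently from the two starting chains: the same change on two cores in this assay, a 2.5-fold higher number (0.41 log units; beyond the scatter) from compound 1 to compound 3 and a 1.3-fold lower number (0.11 log units; within the scatter) from compound 4 to compound 2, 3.3-fold (0.52 log units) apart, beyond the scatter of two such steps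

On these data alone, whether numbers keep rising on a longer chain such as decyl, or level off after compound 3, stays open. Also open, as far as these compounds go, is whether an amine or a carboxylic acid at the end of the chain would stay on the level of compound 4 in this assay.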